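Removing the ring methyl in a nitro-pyrrole cytotoxicity series

The source may report more compounds than this note shows. Statements on the series, on what has been measured and on what is new or still open speak of the compounds shown alone.

Measured so far:
compound 1 `O=C(NNC(=O)c1cc([N+](=O)[O-])c[nH]1)Nc1ccc(Br)cc1`: 378000 nM
compound 2 `COc1cc(NC(=S)NNC(=O)c2cc([N+](=O)[O-])cn2C)cc(OC)c1OC`: 392000 nM
compound 3 `Cn1cc([N+](=O)[O-])cc1C(=O)NNC(=O)Nc1ccc(Br)cc1`: 602000 nM

All three were tested in an ADME assay on Vero cells (Chlorocebus sabaeus) for cytotoxicity, read by MTT assay, with a stated time of 72 h; a lower number here means a stronger inhibitor, a higher number a weaker inhibitor. Compound 3 gives 602000 nM, and compound 1, which differs from it by hydrogen in place of methyl on an aromatic nitrogen, gives 378000 nM. That step is a 1.6-fold lower number from compound 3 to compound 1 (0.20 log units; within the scatter), so the two numbers cannot be told apart with confidence.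

Compound 2 gives 392000 nM. It carries a different core from compound 3, and the difference between the two cores is not broken down here. Among the measured compounds shown here, compound 4 `COc1cc(NC(=S)NNC(=O)c2cc([N+](=O)[O-])c[nH]2)cc(OC)c1OC` is not yet measured; it differs from compound 2 by hydrogen in place of methyl on an aromatic nitrogen, the same change as the one between compound 3 and compound 1, at the same place on the ring.

For the measured compounds named here, the expected step from compound 2 to compound 4 in this assay is a 1.3-fold lower number from compound 2 to compound 4 (0.12 log units; within the scatter), close to the earlier one, because the only measured example of this change is a 1.6-fold lower number from compound 3 to compound 1 (0.20 log units; within the scatter). On that basis compound 4 is estimated at 300000 nM, expected to fall between 150000 nM and 600000 nM.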

Compound 4, half-maximal inhibitory concentration: 328000 nM
Estimate against measurement, compound 4: 1.1-fold (0.04 log units) below, and the stated range covers the measured number.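

In this assay, putting hydrogen in place of the methyl on the ring nitrogen gives a 1.2-fold lower number from compound 2 to compound 4 (0.08 log units; within the scatter), so on this second core the step again cannot be told apart from the ordinary spread of repeated measurements. Set side by side, the two examples of this change do not differ: the same change on two cores in this assay, a 1.6-fold lower number (0.20 log units; within the scatter) from compound 3 to compound 1 and a 1.2-fold lower number (0.08 log units; within the scatter) from compound 2 to compound 4, 1.3-fold (0.12 log units) apart, within the scatter of two such steps. This shows that, across these two cores, the change behaves alike and leaves the reading within the scatter, but it does not show that removing the methyl truly alters the number on either core, and two cores cannot speak for the whole series.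

The compounds shown leave open what other groups on that ring nitrogen would do, for example an ethyl group, a longer chain or a chain ending in a carboxylic acid or an amine. They also leave open whether any such group would give a step beyond the scatter.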